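An Alkene in Place of a Saturated Side Chain

The source may report more compounds than this note shows. Statements on the series, on what has been measured and on what is new or still open speak of the compounds shown alone.

Compound 1 `COc1cccc(C(=O)O[C@H]2C=CC(=O)N3C[C@@H](OC(=O)[C@H](O)[C@H](CC(C)C)NC(=O)OC(C)(C)C)C[C@H]23)c1` and compound 2 `CC(C)C[C@@H]1NC(=O)OCCCc2cccc(c2)C(=O)O[C@H]2C=CC(=O)N3C[C@H](C[C@H]23)OC(=O)[C@@H]1O` share one core and were both tested in a functional assay on MDA-MB-435 cells (Homo sapiens) for cytotoxicity, with a stated time of 72 h; on this read-out higher numbers stand for weaker inhibition and lower numbers for stronger inhibition. In this assay compound 1 gives > 20000 nM, which is a limit of the assay and not a number. In this assay compound 2 gives > 20000 nM, also a limit. Compound 1 therefore stands only at a limit, and the same holds for every value shown: the limit of > 20000 nM in this assay, at which 2 of the 2 values shown sit. Compound 3 `COc1cccc(C(=O)O[C@H]2C=CC(=O)N3C[C@@H](OC(=O)[C@H](O)[C@H](C=C(C)C)NC(=O)OC(C)(C)C)C[C@H]23)c1` differs from compound 1 in one place: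

2-methylprop-1-en-1-yl in place of isobutyl on a saturated chain carbon bound to an amide-type nitrogen and a saturated chain carbon

Going by the values given here, no step between measured compounds exists here, so no measured change can guide the expectation. In this assay the expected step is a number no higher from compound 1 to compound 3 (the limit leaves the size open), no more than the scatter. Compound 3 is expected to give about 20000 nM in this assay, most likely again only as a limit. For compound 3 the expected range runs from 8000 nM to 60000 nM.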

Compound 3, half-maximal inhibitory concentration: 8900 nM
Estimate against measurement, compound 3: 2.2-fold (0.35 log units) above, within the range that was stated.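

This chain carbon, bound to an amide-type nitrogen, proves sensitive to a small change: with the same count of heavy atoms, 2-methylprop-1-en-1-yl in place of isobutyl gives an at least 2.2-fold lower number from compound 1 to compound 3 (0.35 log units; beyond the scatter) in this assay. Going by these compounds alone, compound 3 thereby gives an actual number, where the earlier compounds offered only limits, so later changes to this core have a measured value to be compared against. The step shows only a minimum size, and its true size remains unknown: the limit of > 20000 nM in this assay, at which 2 of the 3 values shown sit.

From the compounds shown here alone, whether the same exchange would also give a measurable number on compound 2 remains open. Also open, going by these compounds, is how a phenyl group, a cyclopropyl group or a longer chain on this carbon would compare with 2-methylprop-1-en-1-yl.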